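Swapping the Aryl Group on a Cyclohexyl Urea

A few compounds are considered here, and "the series" means these few. Any claim that something is new, unique, unknown or untested is made for them only; others in the source may bear on it.

The two measured compounds are compound 1 `O=C(Nc1cccc(C(F)(F)F)c1)N[C@H]1CC[C@H](O)CC1` and compound 2 `O=C(Nc1ccc(Br)cc1)N[C@H]1CC[C@H](Oc2ccc(F)cc2)CC1`. Both were tested in a functional assay on CRL2813 cells (Homo sapiens) for cytotoxicity, read by sulforhodamine B assay, with a stated time of 5 days; on this read-out higher numbers stand for weaker inhibition and lower numbers for stronger inhibition. In this assay compound 1 gives > 20000 nM, which is a limit of the assay rather than a number. In this assay compound 2 likewise gives only a limit, > 20000 nM. Compound 2 therefore stands at the limit of > 20000 nM in this assay, at which 2 of the 2 values shown sit, and no number separates it from compound 1.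

Compound 3 `Cc1cccc(NC(=O)N[C@H]2CC[C@H](Oc3ccc(F)cc3)CC2)c1` has not yet been measured in this assay. It differs from compound 2 by 3-methylphenyl in place of 4-bromophenyl on an amide-type nitrogen. Among the compounds with values here, no measured pair shows what this change does here, so the expectation rests only on where compound 2 sits. The expected step in this assay is a step that the limit leaves unreadable from compound 2 to compound 3, no more than the usual scatter, with compound 3 most likely remaining at the limit. Compound 3 is expected to give about 25000 nM in this assay, within a range from 8000 nM to 80000 nM.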

Compound 3, half-maximal inhibitory concentration: 14400 nM
Estimate against measurement, compound 3: 1.7-fold (0.24 log units) above; the measured number falls inside the stated range.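

Within the data shown here, compound 3 is the first compound here to give a number rather than a limit of the assay: in this assay compound 3 gives 14400 nM. Placing 3-methylphenyl where 4-bromophenyl stood on the amide-type nitrogen gives an at least 1.3-fold lower number from compound 2 to compound 3 (0.14 log units; that floor lies within the scatter), so a readable value appears, but a real gain is not established. The full size of this step cannot be read because compound 2 has only a limit: the limit of > 20000 nM in this assay, at which 2 of the 3 values shown sit.

The compounds shown do not separate the effect of replacing bromine with methyl from the effect of going from a 4-substituted to a 3-substituted phenyl group. They also leave open what an amine or a carboxylic acid on this phenyl ring would do.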